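A few compounds are considered here, and "the series" means these few. Any claim that something is new, unique, unknown or untested is made for them only; others in the source may bear on it.

Compound 2 `CC1=C(C(=O)Nc2ccccc2Cl)C(c2ccccc2Br)NC(=O)N1` was examined in an ADME assay on Vero cells (Chlorocebus sabaeus) for cytotoxicity, read by XTT assay, with a stated time of 72 h; a higher number here means that more compound is tolerated, a lower number that less compound is tolerated. In this assay compound 2 gives only a limit, > 100000 nM. Compound 1 `CC1=C(C(=O)Nc2ccccc2Cl)C(c2ccccc2Cl)NC(=S)N1` likewise gives only a limit in this assay, > 100000 nM. Both results share one feature: the limit of > 100000 nM in this assay, at which 2 of the 2 values shown sit. Compound 3 `CC1=C(C(=O)Nc2ccccc2Cl)C(c2cccs2)NC(=O)N1` is not yet measured; it differs from compound 2 in that (thiophen-2-yl in place of 2-bromophenyl on a saturated ring carbon). Among the compounds with values here, no step between measured compounds is available, so no direction can be drawn from them. The step of a number no higher from compound 2 to compound 3 (the limit leaves the size open) is expected to stay within the scatter, because compound 2 gives > 100000 nM. Compound 3 is therefore estimated at about 100000 nM, between 50000 nM and 200000 nM, most likely again reported only as a limit.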

Compound 3, half-maximal cytotoxic concentration: > 100000 nM
Compound 3 gave a limit, no number; the forecaster's own chance of this, stated with the estimate: 80%; the middle value sits exactly at the limit.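

No step can be read from compound 2 to compound 3 in this assay, as both results are limits and not numbers: the limit of > 100000 nM in this assay, at which 3 of the 3 values shown sit.

The compounds shown leave open where the half-maximal cytotoxic concentration of each actually lies, and whether thiophen-2-yl in place of 2-bromophenyl changes it.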